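The source may report more compounds than this note shows. Statements on the series, on what has been measured and on what is new or still open speak of the compounds shown alone.

Compound 1, `C=CC[N+](C)(C)c1cccc(OC)c1`, in a functional assay with Cavia porcellus as the target; a lower number here means a stronger inhibitor, a higher number a weaker inhibitor: > 3000 nM, a limit of the assay rather than a number.
Compound 2, `C=C(C)C[N+](C)(C)c1cccc(O)c1`, in this assay: > 3000 nM, again a limit and not a number.

For the measured compounds named here, compound 2 therefore has no measured value of its own to stand on; it sits at the edge of what this assay reports, and the only other compound measured sits at the same edge (the limit of > 3000 nM in this assay, at which 2 of the 2 values shown sit). Going by the values given here, no step between two measured compounds can be drawn from two limits, so nothing about direction or size of any structural change can be read from these data.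

Compound 3, `C=C(C)C[N+](C)(C)c1cccc(OC)c1`, differs from compound 2 by methyl in place of hydrogen on an oxygen on an aromatic ring; cut one bond further out, the same difference reads hydroxy to methoxy. Since both measured compounds give only a limit in this assay, no step beyond the scatter is expected in either direction, and the likeliest outcome is a further limit. Compound 3 is expected at 6000 nM, within a range from 2000 nM to 20000 nM. The step that this estimate means, a step that the limit leaves unreadable from compound 2 to compound 3, is expected to be small.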

Compound 3, half-maximal inhibitory concentration: > 3000 nM
Compound 3 ended at the assay's limit; the forecaster's own chance of this, stated with the estimate: 80%; the middle value lies beyond the limit too.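

For the compounds shown here, no step to compound 3 can be read, from compound 2 or from compound 1, since all three compounds end at a limit of the assay rather than at a number: the limit of > 3000 nM in this assay, at which 3 of the 3 values shown sit.

The compounds shown leave open whether hydroxy to methoxy, or methyl in place of hydrogen on the double-bonded chain carbon, changes the result in this assay at all.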